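The source may hold more compounds than are shown below. What is called first, only, known or untested is meant among the compounds shown, and "the series" means these compounds.

Of the compounds shown here, three sharing one core have been tested in a functional assay on HT-29 cells (Homo sapiens) for cytotoxicity, read by MTT assay, with a stated time of 72 h; a higher number here means a weaker inhibitor, a lower number a stronger inhibitor. Compound 1 `CN(C)CCn1cnnc1-c1cc(Oc2ccc(NC(=O)N/N=C/c3cccc(Cl)c3Cl)cc2F)ccn1` gives 130 nM. Compound 3 `CN(C)CCn1cnnc1-c1cc(Oc2ccc(NC(=O)N/N=C/c3ccc(Cl)cc3Cl)cc2F)ccn1` gives 390 nM. Compound 2 `CN(C)CCn1cnnc1-c1cc(Oc2ccc(NC(=O)N/N=C/c3ccc(O)c(F)c3)cc2F)ccn1` gives 3310 nM, the highest number of the three: its nearest neighbour is compound 3 at an 8.5-fold lower number from compound 2 to compound 3 (0.93 log units; beyond the scatter), and the step of a 25-fold higher number from compound 1 to compound 2 (1.41 log units; beyond the scatter) is larger still. Compound 4 `CN(C)CCn1cnnc1-c1cc(Oc2ccc(NC(=O)N/N=C/c3ccc(O)cc3O)cc2F)ccn1` is not yet measured; it differs from compound 2 by 2,4-dihydroxyphenyl in place of 3-fluoro-4-hydroxyphenyl on a carbon with a double bond to nitrogen. The two steps already seen both swap a hydroxy-bearing ring for a dichlorophenyl or back, and both moved the number a great deal; none of them exchanges one hydroxy-bearing ring for another, so they offer only a weak guide. Since 2,4-dihydroxyphenyl keeps a hydroxy group like 3-fluoro-4-hydroxyphenyl does, the number for compound 4 is expected to stay close to that of compound 2, with a step of about a 1.1-fold higher number from compound 2 to compound 4 (0.02 log units; within the scatter), likely within the scatter. The estimate for compound 4 in this assay is 3500 nM, within a range from 1200 nM to 10000 nM.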

Compound 4, half-maximal inhibitory concentration: 52600 nM
Compound 4: the middle estimate sits 15-fold (1.18 log units) below what was measured; the measured number lies above the stated range.
By their numbers in this assay, from the lowest: compound 1; then compound 3; then compound 2; then compound 4.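

In this assay, for the compounds shown here, keeping a hydroxy group on the ring does not hold the number steady: a 16-fold higher number from compound 2 to compound 4 (1.20 log units; beyond the scatter) shows that two hydroxy-bearing rings can differ widely, something the earlier steps, each with a dichlorophenyl on at least one side, could not show. The gaps to the dichlorophenyl compounds also grow, to a 130-fold higher number from compound 3 to compound 4 (2.13 log units; beyond the scatter) and a 400-fold higher number from compound 1 to compound 4 (2.61 log units; beyond the scatter), which makes compound 4 the weakest of the four and shows how far this position alone can move the number. No accompanying measurement offers an explanation for these steps.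

The change removes a fluorine and adds a hydroxy group at once, and the compounds shown do not separate the two. As far as these compounds go, how a ring carrying a methoxy group or an amine at this position would behave also stays open.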